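Aryl swap on the fused oxolane core: compound 1 to 4

The source may report more compounds than this note shows. Statements on the series, on what has been measured and on what is new or still open speak of the compounds shown alone.

Measured so far:
- compound 1, `C=C(C)[C@H]1CC(=O)C(C)=C2[C@@H](C(=O)OCC)O[C@@H](c3ccc(Cl)cc3Cl)[C@@H]21`: in a functional assay on KB3 cells (Homo sapiens) for antiproliferative activity, read by MTT assay, with a stated time of 96 h (on this read-out lower numbers stand for stronger inhibition and higher numbers for weaker inhibition), compound 1 gives 3000 nM.
- compound 2, `C=C(C)[C@H]1CC=C(C)C2=CO[C@@H](c3cccc4ccccc34)[C@@H]21`: in this assay compound 2 reaches only the assay limit > 100000 nM, not a number.
- compound 3, `C=C(C)[C@H]1CC=C(C)[C@H]2[C@@H]1[C@H](c1ccccc1Br)O[C@@H]2C(=O)OCC`: in this assay compound 3 likewise stops at the limit > 100000 nM.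

Among the compounds with values here, compound 1 is the only member of the set with a measured number; the other two sit at the limit of > 100000 nM in this assay, at which 2 of the 3 values shown sit, so no measured step between compounds exists here, and no pattern across the aryl groups can be drawn from them.

The next compound, compound 4, `C=C(C)[C@H]1CC(=O)C(C)=C2[C@@H](C(=O)OCC)O[C@@H](c3cccc(Br)c3)[C@@H]21`, keeps the core of compound 1 and changes only the aryl group: 3-bromophenyl in place of 2,4-dichlorophenyl on a saturated ring carbon.

Within the data shown here, with no measured step to lean on, the expectation rests on compound 1 alone. A halogenated phenyl remains, so compound 4 is expected to stay measurable rather than fall to the limit, but the change is expected to cost some potency: a 2.0-fold higher number from compound 1 to compound 4 (0.30 log units; within the scatter) is the step estimated, a modest weakening. Compound 4 is therefore estimated at 6000 nM, within a range from 1500 nM to 30000 nM.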

Compound 4, half-maximal inhibitory concentration: 30000 nM
Estimate against measurement, compound 4: 5.0-fold (0.70 log units) below; the measured number falls inside the stated range.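

Within the data shown here, on the core of compound 1, this assay now gives a first measured step for the aryl group on the saturated ring carbon next to the ring oxygen: a 10-fold higher number from compound 1 to compound 4 (1.00 log units; beyond the scatter) with 3-bromophenyl in place of 2,4-dichlorophenyl. Among these compounds, the earlier compounds offered no such step, so this is the first sign that the read-out responds to the aryl group at this position on this core, although one pair cannot set a trend. Compound 4 still gives a number, while compound 2 and compound 3 stay at a limit and fall outside any comparison of steps:  the limit of > 100000 nM in this assay, at which 2 of the 4 values shown sit.

The single step changes the kind of halogen, the number of halogens and their ring positions together, so the compounds shown cannot assign it to any one of these. Also open, as far as these compounds go, is how this position on the core of compound 1 would respond to an unsubstituted phenyl, or to a phenyl carrying an amine or a carboxylic acid in place of halogen.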